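Aryl replacing carbamate-capped pyrrolidine on the imidazole nitrogen

The compounds below may be only part of what the source reports. "The series", "measured", "known", "first", "only" and "open" are said of these compounds alone.

Compound 3 `CN1CCN(c2ccc(Nc3ncc4nc(Nc5ccc(F)cc5)n([C@H]5CCN(C(=O)OC(C)(C)C)C5)c4n3)cc2)CC1` gives 580 nM in a functional assay on HCC827 cells (Homo sapiens) for antiproliferative activity, read by MTT assay, with a stated time of 72 h (a lower number here means a stronger inhibitor, a higher number a weaker inhibitor), the highest of the three numbers; compound 1 `CN1CCN(c2ccc(Nc3ncc4nc(Nc5ccc(F)cc5)n([C@@H]5CCN(C(=O)CO)C5)c4n3)cc2)CC1` at 350 nM sits within the scatter of it, compound 2 `CN1CCN(c2ccc(Nc3ncc4nc(Nc5ccc(F)cc5)n(-c5cccc(NC(=O)CO)c5)c4n3)cc2)CC1` at 7.5 nM far below. Compound 4 `CC(=O)Nc1cccc(-n2c(Nc3ccc(F)cc3)nc3cnc(Nc4ccc(N5CCN(C)CC5)cc4)nc32)c1` differs from compound 3 by 3-acetamidophenyl in place of 1-(tert-butoxycarbonyl)pyrrolidin-3-yl on an aromatic nitrogen. Within the data shown here, two measured steps bear on this: a 77-fold higher number from compound 2 to compound 3 (1.89 log units; beyond the scatter) and a 47-fold lower number from compound 1 to compound 2 (1.67 log units; beyond the scatter), both large and both tying the aryl substituent bearing an amide to the low numbers. The acetamide of compound 4 is a close relative of the hydroxyacetamide of compound 2, so a large drop is expected, a 48-fold lower number from compound 3 to compound 4 (1.68 log units; beyond the scatter), landing near compound 2. For compound 4 the estimate in this assay is 12 nM, ranging from 4 nM to 40 nM.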

Compound 4, half-maximal inhibitory concentration: 10 nM
Beside the measured number, compound 4's estimate is 1.2-fold (0.08 log units) above it; the range from low to high includes it.
By their numbers in this assay, from the lowest: compounds 2 and 4 (each within the scatter of the next); then compounds 1 and 3 (each within the scatter of the next).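

In this assay, a 1.3-fold higher number from compound 2 to compound 4 (0.12 log units; within the scatter) shows that hydrogen in place of hydroxy on the chain carbon bound to the carbonyl carbon stays within the scatter, so the low number does not depend on that hydroxy. The aryl advantage over both pyrrolidines also holds with the plain 3-acetamidophenyl group, with a 58-fold lower number from compound 3 to compound 4 (1.76 log units; beyond the scatter) and a 35-fold lower number from compound 1 to compound 4 (1.54 log units; beyond the scatter), both large. No measurement at hand explains these steps.

Open, on these data alone, is whether the acetamide is needed at all: an amine or a carboxylic acid in its place on the phenyl ring, or a longer chain on the carbonyl, could still hold or lose the low number.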